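This account rests on a few compounds, and the source may have more. Where it says the series, first, only, none or still open, it means among the compounds named here.

Within the data shown here, in an ADME assay on KB cells (Homo sapiens) for cytotoxicity (a higher number here means that more compound is needed for the effect, a lower number that less compound is needed), compound 3 `CCCCOc1c(OC)c(OC)cc2c1C(=O)[C@]1(OC)C=C[C@H]2N(C(=O)OCC(C)C)N1C(=O)OCC(C)C` gives 22.1 ug/mL, the lowest number so far. Compound 2 `COc1ccc(COc2c(OC)c(OC)cc3c2C(=O)[C@]2(OC)C=C[C@H]3N(C(=O)OCC(C)C)N2C(=O)OCC(C)C)cc1` gives 47.9 ug/mL. Compound 1 `COc1cc2c(c(OCc3ccc(F)cc3)c1OC)C(=O)[C@]1(OC)C=C[C@H]2N(C(=O)OCC(C)C)N1C(=O)OCC(C)C` reads > 300 ug/mL, which is a limit of the assay and not a number.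

Compound 4 `COc1cc2c(c(OCc3ccc(Cl)cc3)c1OC)C(=O)[C@]1(OC)C=C[C@H]2N(C(=O)OCC(C)C)N1C(=O)OCC(C)C` differs from compound 3 at one place: 4-chlorophenyl in place of propyl on a saturated chain carbon bound to an oxygen on an aromatic ring. In words, this is 4-chlorophenyl in place of propyl on a saturated chain carbon bound to an oxygen on an aromatic ring.

Among the measured compounds shown here, two measured steps bear on this change, both made in the opposite structural direction. These are the modest 2.2-fold lower number from compound 2 to compound 3 (0.34 log units; beyond the scatter) and the large at least 13-fold lower number from compound 1 to compound 3 (1.13 log units; beyond the scatter), the second resting on a limit. The an at least 6.2-fold lower number from compound 1 to compound 2 (0.79 log units; beyond the scatter) also shows that the outcome depends on the group carried by the aromatic ring. Reversing the direction, a modest to large rise in the number is expected, estimated as a 3.6-fold higher number from compound 3 to compound 4 (0.56 log units; beyond the scatter). For compound 4 the estimated value is 80 ug/mL, with an expected range of 28 ug/mL to 300 ug/mL.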

Compound 4, concentration for half-maximal effect: 42 ug/mL
Compound 4: middle estimate off by 1.9-fold (0.28 log units), on the high side, within the range that was stated.
By their numbers in this assay, from the lowest: compounds 3, 4 and 2 (each within the scatter of the next, the first and the last beyond it). At a limit, above all of these: compound 1.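

With 4-chlorophenyl in place of propyl on the saturated chain carbon bound to an oxygen on an aromatic ring, the data show a 1.9-fold higher number from compound 3 to compound 4 (0.28 log units; within the scatter), so this assay does not separate these two groups, and an aromatic ring at this place is compatible with a measurable number. Chloro and methoxy on the aromatic carbon are not separated either, with a 1.1-fold lower number from compound 2 to compound 4 (0.06 log units; within the scatter). Among the three groups compared on that carbon, only fluoro stands apart, with an at least 7.1-fold lower number from compound 1 to compound 4 (0.85 log units; beyond the scatter), and this step rests on the limit for compound 1: the limit of > 300 ug/mL in this assay, at which 1 of the 4 values shown sits.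

As far as these compounds go, the true size of the chloro-for-fluoro step remains open, since compound 1 gives no number. Also open, from the compounds shown here alone, is how bromo, trifluoromethyl or an amine on the aromatic carbon would read, or a hexyl chain in place of butyl.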